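Removing the para-chloro on the piperazine aryl group

The source may hold more compounds than are shown below. What is called first, only, known or untested is meant among the compounds shown, and "the series" means these compounds.

Measured so far in a functional assay on the whole organism (strain Swiss) with Mus musculus as the target, in the maximal electroshock model, with a stated time of 0.5 h, at a dose of 100 mg/kg by the intraperitoneal route; a higher number here means a stronger effect of the compound at the dose given, a lower number a weaker effect:
compound 1 `CC(C(=O)N1CCN(c2ccc(Cl)cc2)CC1)N1C(=O)CCC1=O`: 25%
compound 2 `CCC(C(=O)N1CCN(c2cccc(F)c2)CC1)N1C(=O)CCC1=O`: 0%
compound 3 `CCC(C(=O)N1CCN(c2cccc(C(F)(F)F)c2)CC1)N1C(=O)CCC1=O`: 50%

Compound 1 stands second of the three numbers in this assay: compound 2 gives 0% and compound 3 gives 50%, both steps away from compound 1 beyond the scatter. Compound 4 `CC(C(=O)N1CCN(c2ccccc2)CC1)N1C(=O)CCC1=O` has not been measured; it differs from compound 1 by hydrogen in place of chloro on an aromatic carbon.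

Going by the values given here, only one measured step changes a single place on the aromatic ring: a number 50 percentage points higher from compound 2 to compound 3 (beyond the scatter). That step exchanges one group for another at a different position and shows that a substituent on this ring can move the number by a large amount. Among the compounds with values here, no measured pair removes a group from the ring altogether, so the size of the present step is not well anchored. Taken together with compound 1 giving 25%, the expectation is a modest fall, a number 10 percentage points lower from compound 1 to compound 4 (within the scatter), with a wide uncertainty.

Compound 4 is therefore estimated at 15% in this assay, within a range from 0% to 40%.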

Compound 4, a percentage reported as activity, at one dose (the size of the read-out at that dose, not a potency): 0%
Compound 4: the middle estimate sits 15 percentage points above what was measured; measured number inside the range.
By their numbers in this assay, from the lowest: compounds 2 and 4 (each within the scatter of the next); then compound 1; then compound 3.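

In this assay, going by these compounds alone, the change from 4-chlorophenyl to phenyl gives a number 25 percentage points lower from compound 1 to compound 4 (beyond the scatter), the first measured step that removes a group from this ring instead of exchanging one group for another. With the rest of the structure held constant, the chloro on this aromatic carbon, para to a large group, is therefore needed for the effect seen in compound 1 at this dose, and compound 4 gives 0%. No measurement at hand gives a reason for this fall.

On these data alone, whether chloro is special at this carbon or whether another group, such as bromo, methoxy or an amine, would restore or exceed the number remains open, since this pair compares chloro only with hydrogen. A reading at one dose and one time also leaves open whether compound 4 is inactive in general or shows an effect at another dose or time, and whether removing chloro would cost as much with a longer chain on the core.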